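A few compounds are considered here, and "the series" means these few. Any claim that something is new, unique, unknown or untested is made for them only; others in the source may bear on it.

Measured so far in a functional assay on MOLT-3 cells (Homo sapiens) for cytotoxicity, read by MTT assay, with a stated time of 48 h; a higher number here means a weaker inhibitor, a lower number a stronger inhibitor:

Compound 1 `O=Cc1ccc(OCc2cn(-c3ccc(S(=O)(=O)N4CCc5ccccc5C4)cc3)nn2)cc1` gives > 50 ug/mL.
Compound 2 `O=S(=O)(c1ccc(-n2cc(COc3ccccc3)nn2)cc1)N1CCc2ccccc2C1` gives > 50 ug/mL.

Both values are limits of the assay rather than numbers. Compound 2 therefore stands only at a limit, and nothing places it more precisely than that. Going by the values given here, the single measured step, a step that the two limits leave unreadable from compound 1 to compound 2, is a step between two limits, so its size cannot be read; the only evidence on the numbers is the limit of > 50 ug/mL in this assay, at which 2 of the 2 values shown sit.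

Compound 3 `O=S(=O)(c1ccc(-n2cc(COc3ccc4ccccc4c3)nn2)cc1)N1CCc2ccccc2C1` is the next compound to be measured. It differs from compound 2 in one place: naphthalen-2-yl in place of phenyl on an oxygen on a saturated carbon. Among the compounds with values here, no measured step concerns this kind of change. Within the data shown here, the one step available, from compound 1 to compound 2, is unreadable and touches a different part of the molecule, so it gives no direction or size for the present change. On the numbers at hand, compound 3 is expected to sit again near the limit, with a step of an at least 1.1-fold lower number from compound 2 to compound 3 (0.04 log units; that floor lies within the scatter) that is not expected to exceed the scatter. The estimate for compound 3 in this assay is 45 ug/mL, within 15 ug/mL to 100 ug/mL.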

Compound 3, half-maximal inhibitory concentration: > 50 ug/mL
Compound 3: a limit, no number (the forecaster's own chance of this, stated with the estimate: 65%); middle value at least 1.1-fold (0.04 log units) away from the limit.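

In this assay compound 3 gives > 50 ug/mL, a limit of the assay and not a number. The steps to compound 3 from compound 1 and from compound 2 each join two limits, and neither can be read. The compounds shown leave open how far any of them lies from that limit, and whether naphthalen-2-yl in place of phenyl alters the read-out at all.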